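A few compounds are considered here, and "the series" means these few. Any claim that something is new, unique, unknown or untested is made for them only; others in the source may bear on it.

Working notes on the series in a functional assay on CCRF-CEM cells (Homo sapiens), read by MTT assay, with a stated time of 72 h; on this read-out lower numbers stand for stronger inhibition and higher numbers for weaker inhibition.

Compound 1 `COc1cc(NC(C)CCCNC(=O)NCc2ccncc2)c2ncccc2c1` gives 2900 nM in this assay. Compound 2 `CCN(CC)C(=O)NCCCC(C)Nc1cc(OC)cc2cccnc12` gives 142000 nM in this assay. Among the compounds with values here, the one measured step, a 49-fold higher number from compound 1 to compound 2 (1.69 log units; beyond the scatter), shows what the replacement of the ((pyridin-4-yl)methyl)amino on the carbonyl carbon by diethylamino did. Within the data shown here, compound 2 thus stands at the highest of the two numbers so far, with compound 1 as its only neighbour.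

Compound 3 `COc1cc(NC(C)CCCNC(=O)NCC2CCCCC2)c2ncccc2c1` is not yet measured. It differs from compound 2 in one place: (cyclohexylmethyl)amino in place of diethylamino on a carbonyl carbon. This reverses the type of change seen in the measured step: a diethylamino on the carbonyl carbon gives way once more to a mono-substituted amino bearing a ring, here a saturated one instead of the pyridine of compound 1. The step from compound 1 to compound 2 was large, so the bearing evidence points to a large step downward in this assay for compound 3, because a 49-fold higher number from compound 1 to compound 2 (1.69 log units; beyond the scatter) went the other way. Compound 3 is therefore expected to land near compound 1, with an estimated step of a 36-fold lower number from compound 2 to compound 3 (1.55 log units; beyond the scatter). The estimate for compound 3 is 4000 nM, with a range of 800 nM to 20000 nM.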

Compound 3, half-maximal inhibitory concentration: 22000 nM
The estimate for compound 3 lay 5.5-fold (0.74 log units) below the measured number; measured number above the stated range.
By their numbers in this assay, from the lowest: compound 1; then compound 3; then compound 2.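

In this assay, (cyclohexylmethyl)amino in place of diethylamino on the carbonyl carbon gives a 6.5-fold lower number from compound 2 to compound 3 (0.81 log units; beyond the scatter) and so improves on compound 2, but a mono-substituted amino bearing a ring does not by itself restore the level of compound 1. The kind of ring also counts, a point the earlier pair could not show: cyclohexyl in place of pyridin-4-yl on a saturated chain carbon bound to an amide-type nitrogen gives a 7.6-fold higher number from compound 1 to compound 3 (0.88 log units; beyond the scatter) and separates two groups that both carry the amide hydrogen. The order pyridin-4-yl, cyclohexyl, diethylamino rests on these three compounds alone, and nothing measured here gives a reason for it.

The compounds shown cannot tell whether the gap to compound 1 follows the ring nitrogen or the aromatic ring, and a phenyl at the same chain carbon would bear on that question. Also open, on these data alone, are how a pyridin-3-yl would compare with the pyridin-4-yl and whether a longer chain to the ring would change the number.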